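Fluoro to trifluoromethyl on the shared core

A few compounds are considered here, and "the series" means these few. Any claim that something is new, unique, unknown or untested is made for them only; others in the source may bear on it.

Compound 1 `CC#C[C@@H](Cc1nnn[nH]1)c1ccc(OCc2ccc3scc(-c4ccc(OCCOC)cc4C)c3c2)cc1`: 0.717 h
Compound 2 `CC#C[C@@H](Cc1nnn[nH]1)c1ccc(OCc2ccc3sc(F)c(-c4ccc(OCCOC)cc4C)c3c2)cc1`: 1.95 h

In an ADME assay on microsomes from liver (Homo sapiens) for metabolic stability (a lower number here means that the compound disappears faster, a higher number that the compound lasts longer), compound 2 has the higher of the two measured numbers, at 1.95 h. Compound 3 `CC#C[C@@H](Cc1nnn[nH]1)c1ccc(OCc2ccc3sc(C(F)(F)F)c(-c4ccc(OCCOC)cc4C)c3c2)cc1` carries trifluoromethyl in place of fluoro on an aromatic carbon. Among the measured compounds shown here, one measured step bears on this change: fluoro in place of hydrogen on the same carbon, a 2.7-fold higher number from compound 1 to compound 2 (0.43 log units; beyond the scatter). That step is modest but beyond the scatter. For the measured compounds named here, it starts from hydrogen, and no compound with trifluoromethyl has a measured value, so it gives only a loose guide. The direction of that step suggests a small further rise, and the expected step is a 1.3-fold higher number from compound 2 to compound 3 (0.12 log units; within the scatter), which may not exceed the scatter. For compound 3 the estimated half-life is 2.6 h, with an expected range of 1.1 h to 6 h.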

Compound 3, half-life: > 3 h
Compound 3 ended at the assay's limit (the forecaster's own chance of this, stated with the estimate: 5%); at least 1.1-fold (0.06 log units) between middle value and limit.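

In this assay compound 3 gives > 3 h, which is a limit of the assay and not a number: the limit of > 3 h in this assay, at which 1 of the 3 values shown sits. Measured against hydrogen on this carbon next to the ring sulfur, trifluoromethyl gives an at least 4.1-fold higher number from compound 1 to compound 3 (0.62 log units; beyond the scatter), so a second substituent here also stands clear of the scatter. Measured against fluoro, the change gives an at least 1.5-fold higher number from compound 2 to compound 3 (0.18 log units; that floor lies within the scatter), and this floor alone does not settle whether trifluoromethyl outlasts fluoro.

From the compounds shown here alone, how far compound 3 lies past the limit remains open, and with it the full size of both steps. Also open, going by these compounds, is whether the rise is particular to fluorinated groups, a question that a chloro or a nitrile on the same carbon would bear on.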